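The compounds below may be only part of what the source reports. "The series", "measured", "known", "first", "only" and "open" are said of these compounds alone.

The whole set shares one core, seen in compound 1 `Nc1nc(NC2CC2)c2ncn(/C=C3/CC3(CO)CO)c2n1`. In an ADME assay on MOLT-3 cells (Homo sapiens) for cytotoxicity, with a stated time of 7 days (a higher number here means that more compound is tolerated, a lower number that less compound is tolerated), compound 1 gives only a limit of the assay, > 20000 nM. Compound 3 `CCCCCCOc1nc(N)nc2c1ncn2/C=C1/CC1(CO)CO` carries hexyloxy in place of cyclopropylamino on an aromatic carbon. In this assay compound 3 likewise gives only a limit, > 20000 nM. Within the data shown here, the one step between measured compounds, a step that the two limits leave unreadable from compound 1 to compound 3, cannot be sized because both of its values rest at the limit of > 20000 nM in this assay, at which 2 of the 3 values shown sit. Compound 2 `Nc1nc(N2CCCC2)c2ncn(/C=C3/CC3(CO)CO)c2n1` has no number in this assay at all: its result is "not determined" (no result reported), so compound 2 stands on none of the values shown.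

Compound 4 `CCCCSc1nc(N)nc2c1ncn2/C=C1/CC1(CO)CO` differs from compound 2 by butylsulfanyl in place of pyrrolidin-1-yl on an aromatic carbon. Among the measured compounds shown here, no measured step bears on this exchange, and the single step that exists in this assay is itself unreadable. What can be said is that every number reported so far is a limit, with two of three values sitting at the limit of > 20000 nM in this assay, at which 2 of the 3 values shown sit, which gives no sign of a change beyond the scatter in either direction. Compound 4 is therefore expected to give 30000 nM in this assay, within a range from 10000 nM to 100000 nM, most likely again reported as a limit.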

Compound 4, half-maximal cytotoxic concentration: > 20000 nM
Compound 4 was reported as a limit; the forecaster's own chance of this, stated with the estimate: 75%; the middle value is on the limit's open side.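

Neither the step from compound 1 to compound 4 nor the step from compound 3 to compound 4 can be read, because all three compounds rest at the same limit: the limit of > 20000 nM in this assay, at which 3 of the 4 values shown sit.

The compounds shown leave open whether exchanging cyclopropylamino, hexyloxy or butylsulfanyl on the shared core changes the concentration tolerated in this assay at all.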